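From Hydroxymethyl to Piperidin-1-yl on the Carbonyl

The source may report more compounds than this note shows. Statements on the series, on what has been measured and on what is new or still open speak of the compounds shown alone.

Of the compounds shown here, two have been measured so far. Compound 1 `CCOC(=O)N1CCC(NS(=O)(=O)c2ccc(C(=O)Nc3ccccc3C)c3ccccc23)CC1` in an assay on L1.2 cells for binding affinity to C-C chemokine receptor type 8 (Homo sapiens) (a higher number here means a weaker inhibitor, a lower number a stronger inhibitor), gives 5.21 nM. Compound 2 `Cc1ccccc1C(=O)Nc1ccc(S(=O)(=O)NC2CCN(C(=O)CO)CC2)c2ccccc12` gives 5.4 nM in this assay; this is the higher of the two numbers, but the gap to compound 1 lies within the scatter of repeated measurements, so the two cannot be told apart on the numbers shown.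

Compound 3 `Cc1ccccc1C(=O)Nc1ccc(S(=O)(=O)NC2CCN(C(=O)N3CCCCC3)CC2)c2ccccc12` has not yet been measured. Compared with compound 2, the difference is piperidin-1-yl in place of hydroxymethyl on a carbonyl carbon. Among the measured compounds shown here, no step between two measured compounds has been recorded, so there is no earlier pair to lean on; the only guide is that the two measured compounds, which differ at the same part of the structure, sit close together.

On that basis the author expects a change of at most modest size in this assay, in no particular direction, and most likely one that stays within the scatter, that is a 1.2-fold higher number from compound 2 to compound 3 (0.08 log units; within the scatter). Compound 3 is therefore estimated to give about 6.5 nM in this assay, with a likely range from 2 nM to 20 nM.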

Compound 3, inhibition constant: 4.2 nM
For compound 3 the middle estimate is 1.5-fold (0.19 log units) above the measured one; the range from low to high includes it.
By their numbers in this assay, from the lowest: compounds 3, 1 and 2 (each within the scatter of the next).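

Piperidin-1-yl in place of hydroxymethyl on a carbonyl carbon gives a 1.3-fold lower number from compound 2 to compound 3 (0.11 log units; within the scatter) in this assay, so the two compounds cannot be told apart. Among the compounds shown here, this is the first step that can be read at this position, and it shows that the group on the carbonyl carbon can go from 2 heavy atoms with no ring to 6 heavy atoms in a six-membered non-aromatic ring, with the counted hydrogen-bond donor and acceptor of hydroxymethyl gone, and the number stays within the scatter. No measurement is available that would explain this result.

The compounds shown leave open whether this tolerance extends to other groups on the same carbonyl carbon, such as an open-chain amine like diethylamino, a morpholin-4-yl ring or a group carrying a carboxylic acid. For the compounds shown here, they also leave open whether a single step at this position would remain within the scatter for a much longer chain, since the one step available covers only the change from hydroxymethyl to piperidin-1-yl.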